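The source may hold more compounds than are shown below. What is called first, only, known or untested is meant among the compounds shown, and "the series" means these compounds.

Measured in a functional assay on HCT-116 cells (Homo sapiens) for cytotoxicity, read by MTT assay, with a stated time of 48 h; a higher number here means a weaker inhibitor of growth, a lower number a stronger inhibitor of growth:
- compound 1 `Cc1nc2cc(Cl)c(Cl)cc2[nH]1`: 51000 nM
- compound 2 `O=[N+]([O-])c1ccccc1Cn1c(C(F)(F)F)nc2cc(Cl)c(Cl)cc21`: 5900 nM
- compound 3 `Cc1nc2cc(Cl)c(Cl)cc2n1C1CCCC1`: 13000 nM

Of these three, compound 3 has the second highest number, 13000 nM. Compound 4 `CSc1nc2cc(Cl)c(Cl)cc2n1C1CCCC1` carries methylsulfanyl in place of methyl on an aromatic carbon, next to the ring atom that bears a cyclopentyl group: methylsulfanyl in place of methyl on an aromatic carbon.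

For the measured compounds named here, the only measured step, a 3.9-fold lower number from compound 1 to compound 3 (0.59 log units; beyond the scatter), was modest and lies at a different place, so it bears only loosely on this change. Going by the values given here, no measured step isolates a change at this carbon. A small shift toward a lower number is therefore expected, probably no larger than the scatter: the expected step is a 1.4-fold lower number from compound 3 to compound 4 (0.14 log units; within the scatter).

The estimate for compound 4 is 9500 nM, with an expected range of 3500 nM to 25000 nM.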

Compound 4, concentration for 50% growth inhibition: 2900 nM
Beside the measured number, compound 4's estimate is 3.3-fold (0.52 log units) above it; measured number outside the range, below it.
By their numbers in this assay, from the lowest: compound 4; then compound 2; then compound 3; then compound 1.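

In this assay, for the compounds shown here, methylsulfanyl in place of methyl on the aromatic carbon between two ring nitrogen atoms gives a 4.5-fold lower number from compound 3 to compound 4 (0.65 log units; beyond the scatter), so this carbon, which no earlier step touched, does respond to a change of group. The earlier step, a 3.9-fold lower number from compound 1 to compound 3 (0.59 log units; beyond the scatter), was made on the aromatic nitrogen, so changes at both places shift the number in the same direction. Nothing shown gives a reason for the new shift. Still open, going by these compounds, is whether an amine at this carbon, or a longer chain on the sulfur, would lower the number further. It is also unclear whether the shift would hold with another group in place of cyclopentyl.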